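Swapping methyl for phenyl on a second isoxazoline core

The source may report more compounds than this note shows. Statements on the series, on what has been measured and on what is new or still open speak of the compounds shown alone.

Of the compounds shown here, three have been tested so far. Compound 1 `COc1cc(-c2cc(COCc3cn(Cc4cc(-c5ccccc5)cnc4Cl)nn3)on2)cc(OC)c1OC` and compound 2 `COc1cc(-c2cc(COCc3cn(Cc4cc(C)cnc4Cl)nn3)on2)cc(OC)c1OC` share one core, while compound 3 `COc1cc(C2=NOC(COCc3cn(Cc4cc(C)cnc4Cl)nn3)C2)cc(OC)c1OC` is built on a different core; the difference between the two cores is not broken down here. In a functional assay on MCF7 cells (Homo sapiens) for cytotoxicity, read by MTT assay, with a stated time of 48 h (on this read-out higher numbers stand for weaker inhibition and lower numbers for stronger inhibition), compound 1 gives 68500 nM, compound 2 gives 194000 nM, and compound 3 gives 85500 nM. Going by the values given here, the only change from compound 2 to compound 1 is phenyl in place of methyl on an aromatic carbon, and this step gave a 2.8-fold lower number from compound 2 to compound 1 (0.45 log units; beyond the scatter).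

Compound 4 `COc1cc(C2=NOC(COCc3cn(Cc4cc(-c5ccccc5)cnc4Cl)nn3)C2)cc(OC)c1OC` has not yet been measured. It differs from compound 3 by phenyl in place of methyl on an aromatic carbon. Among the compounds with values here, this is the same kind of change as the one from compound 2 to compound 1, made at a place that is described in the same words, but on the other core. Because the earlier change brought a 2.8-fold lower number from compound 2 to compound 1 (0.45 log units; beyond the scatter), a step of similar direction and size is expected here, with the caution that it rests on a single pair and that the core is not the same. Compound 4 is therefore expected to show a step of a 2.7-fold lower number from compound 3 to compound 4 (0.43 log units; beyond the scatter) in this assay. The estimated value for compound 4 in this assay is 32000 nM, with a likely range from 14000 nM to 75000 nM.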

Compound 4, half-maximal inhibitory concentration: 14600 nM
Compound 4: the middle estimate sits 2.2-fold (0.34 log units) above what was measured; measured number inside the range.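

In this assay, putting phenyl in place of methyl gave a 5.9-fold lower number from compound 3 to compound 4 (0.77 log units; beyond the scatter), which points the same way as the earlier 2.8-fold lower number from compound 2 to compound 1 (0.45 log units; beyond the scatter), so the direction of this change carried over from one core to the other. Going by these compounds alone, the second step looks larger, but the two cannot be told apart in size: the same change on two cores in this assay, a 2.8-fold lower number (0.45 log units; beyond the scatter) from compound 2 to compound 1 and a 5.9-fold lower number (0.77 log units; beyond the scatter) from compound 3 to compound 4, 2.1-fold (0.32 log units) apart, within the scatter of two such steps This does not show that one core responds more strongly than the other, and with only one pair on each core it offers no rule for a further core and no explanation of why phenyl gives the lower number.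

The compounds shown leave open how the number would move with something other than methyl or phenyl on that aromatic carbon, such as an ethyl group, an amine or a carboxylic acid. They also leave open whether the same step would appear on a third core, or in any read-out other than this assay.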